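Ring-to-chain swap at the alkylated nitrogen of compound 3

This account rests on a few compounds, and the source may have more. Where it says the series, first, only, none or still open, it means among the compounds named here.

Measured compounds:
Compound 1, `CC(C)n1cnc2c(N(C)C)ncnc21`: 11 mg/kg
Compound 2, `CN(C)c1ncnc2c1ncn2CC1CCC1`: 8 mg/kg
Compound 3, `c1nc(NC2CC2)c2ncn(CC3CCC3)c2n1`: 10 mg/kg

These three compounds share one core and were tested in a functional assay on the whole organism for antagonist activity, with Rattus norvegicus as the target; on this read-out higher numbers stand for an effect only at larger amounts of compound and lower numbers for an effect already at smaller amounts. Compound 3 stands second highest of the three numbers, with compound 1 nearest and compound 2 furthest, and all three values lie within the scatter of one another, so no order among them can be read.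

Compound 4, `CC(C)Cn1cnc2c(NC3CC3)ncnc21`, differs from compound 3 in one place: isopropyl in place of cyclobutyl on a saturated chain carbon bound to an aromatic nitrogen. Within the data shown here, the only measured step that bears on this part of the molecule is the one from compound 1 to compound 2, where cyclobutylmethyl replaced isopropyl on an aromatic nitrogen and the change was a 1.4-fold lower number from compound 1 to compound 2 (0.14 log units; within the scatter). Going from compound 3 to compound 4 cuts the same kind of group back by one ring, and nothing measured suggests a move beyond the scatter.

Compound 4 is therefore expected to give about 10 mg/kg in this assay, estimated between 5 mg/kg and 20 mg/kg, which means an expected step of no change at the digits printed from compound 3 to compound 4 (within the scatter).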

Compound 4, dose for half-maximal effect: 10 mg/kg
The estimate for compound 4 equals the measured number at the digits printed, within the range that was stated.
By their numbers in this assay, from the lowest: compounds 2, 3, 4 and 1 (each within the scatter of the next).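

In this assay, among these compounds, putting isopropyl in place of cyclobutyl on a saturated chain carbon bound to an aromatic nitrogen gives no change at the digits printed from compound 3 to compound 4 (within the scatter) and so adds a direct comparison that the earlier compounds lacked. The step from compound 1 to compound 2 exchanged isopropyl on the nitrogen for cyclobutylmethyl, whereas this pair keeps the carbon attached to the nitrogen and opens the ring, showing that with cyclopropylamino on the core, cyclobutylmethyl and isobutyl cannot be told apart on this read-out. Nothing available explains why the two groups read alike.

The compounds shown leave open what a straight butyl chain, a benzyl group, or a chain ending in an amine or a carboxylic acid would do at this place. As far as these compounds go, it also remains open whether isobutyl and cyclobutylmethyl would read alike with dimethylamino on the core.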